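A few compounds are considered here, and "the series" means these few. Any claim that something is new, unique, unknown or untested is made for them only; others in the source may bear on it.

Compound 1 `Cc1ccc(S(=O)(=O)Nc2ccc(NS(=O)(=O)c3ccc(F)cc3)cc2)cc1`: > 100000 nM
Compound 2 `Cc1ccc(C(=O)O)cc1S(=O)(=O)Nc1ccc(NS(=O)(=O)c2ccc(F)cc2)cc1`: > 100000 nM

In an assay for inhibition of liver carboxylesterase 1 (Homo sapiens), read by spectrophotometry (on this read-out lower numbers stand for stronger inhibition and higher numbers for weaker inhibition), compound 1 gives > 100000 nM, which is a limit of the assay rather than a number. Compound 2 gives > 100000 nM, also a limit. Both values sit at the limit of > 100000 nM in this assay, at which 2 of the 2 values shown sit, and a step that the two limits leave unreadable from compound 1 to compound 2 is therefore not readable. Compound 3 `COc1ccc(S(=O)(=O)Nc2ccc(NS(=O)(=O)c3ccc(F)cc3)cc2)cc1` differs from compound 2 by 4-methoxyphenyl in place of 5-carboxy-2-methylphenyl on a sulfonyl sulfur. Among the compounds with values here, the only measured step offers no size to lean on, and with both measured compounds resting at the limit, no change beyond the scatter is expected in this assay. Compound 3 is estimated at 100000 nM (30000 nM to 300000 nM), an expected step of a number no higher from compound 2 to compound 3 (the limit leaves the size open).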

Compound 3, inhibition constant: > 100000 nM
Compound 3 was reported as a limit (the forecaster's own chance of this, stated with the estimate: 85%); the middle value sits exactly at the limit.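

Within the data shown here, no step among compound 1, compound 2 and compound 3 can be read, because all three values are the same limit of the assay: the limit of > 100000 nM in this assay, at which 3 of the 3 values shown sit. The compounds shown leave open how strongly, if at all, any of the three inhibits the enzyme.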